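This account rests on a few compounds, and the source may have more. Where it says the series, first, only, none or still open, it means among the compounds named here.

Three compounds sharing one core were tested in an assay on isolated protein for inhibition of Amine oxidase [flavin-containing] B (Homo sapiens), read by fluorescence and Amplex Red, with a stated time of 30 min, tested at 100 uM; a higher number here means a stronger effect of the compound at the concentration tested, a lower number a weaker effect. Compound 1, `C=CCNc1nnc(SCC(=O)N(Cc2cccc([N+](=O)[O-])c2)c2ccc(F)cc2)s1`, gives 29.2% in this assay. Compound 2, `CCCNc1nnc(SCC(=O)N(Cc2cccc([N+](=O)[O-])c2)c2ccc(F)cc2)s1`, gives 26.8%. Compound 3, `CCNc1nnc(SCC(=O)N(Cc2cccc([N+](=O)[O-])c2)c2ccc(F)cc2)s1`, gives 22.4%. No other of the three numbers lies below that of compound 3, yet neither path to it rises beyond the scatter: the step is a number 6.8 percentage points lower from compound 1 to compound 3 (within the scatter) and a number 4.4 percentage points lower from compound 2 to compound 3 (within the scatter), and between the other two it is a number 2.4 percentage points lower from compound 1 to compound 2 (within the scatter). The three numbers therefore sit together, and the chain on the nitrogen of the core has so far made no difference that the assay can resolve.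

Compound 4, `CC(C)CNc1nnc(SCC(=O)N(Cc2cccc([N+](=O)[O-])c2)c2ccc(F)cc2)s1`, is the next member. Its change from compound 3 is isopropyl in place of methyl on a saturated chain carbon bound to a nitrogen on an aromatic ring. Among the measured compounds shown here, the steps that bear on it are those along the same chain, all within the scatter, the closest being a number 4.4 percentage points lower from compound 2 to compound 3 (within the scatter), which also adds carbon to the same chain. Compound 4 is therefore expected to show no step beyond the scatter in this assay, with an estimated step of a number 2.6 percentage points higher from compound 3 to compound 4 (within the scatter). The expected value for compound 4 is 25%, with a range from 12% to 40%.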

Compound 4, a percentage reported as inhibition, at one concentration (the size of the read-out at that concentration, not a potency): 24.2%
Estimate against measurement, compound 4: 0.8 percentage points above; measured number inside the range.
By their numbers in this assay, from the lowest: compounds 3, 4, 2 and 1 (each within the scatter of the next).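

Among the compounds shown here, the isobutylamino chain brings the first branched group to this position, and isopropyl in place of methyl gives a step of a number 1.8 percentage points higher from compound 3 to compound 4 (within the scatter) in this assay, so the larger group with its 3 heavy atoms opens no gap that can be resolved. The comparisons with the unbranched chains read the same way, with a number 2.6 percentage points lower from compound 2 to compound 4 (within the scatter) for methyl in place of hydrogen on the chain and a number 5 percentage points lower from compound 1 to compound 4 (within the scatter) for isopropyl in place of vinyl, which places the branched, saturated and unsaturated chains of all four compounds together within the scatter. Nothing available here bears on why these chains give such similar numbers.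

On these data alone, whether a chain that ends in a carboxylic acid or an amine, a much longer chain such as octyl, or a benzyl group on this nitrogen would produce a step beyond the scatter remains open. The compounds shown also leave open what replacing the nitro group or the fluorine elsewhere on the shared core would do to these numbers.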